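This account rests on a few compounds, and the source may have more. Where it says the series, first, only, none or still open, it means among the compounds named here.

Series notes. Compound 1 `CN(C(=O)NC(=O)c1ccc(Cl)cc1Cl)c1nc(C(F)(F)F)c(C(=O)N/N=C/c2ccc(C(F)(F)F)cc2)s1` and compound 2 `CN(C(=O)NC(=O)c1cccc(C(F)(F)F)c1)c1nc(C(F)(F)F)c(C(=O)N/N=C/c2ccc(C(F)(F)F)cc2)s1` share one core, carrying either a 2,4-dichlorophenyl or a 3-(trifluoromethyl)phenyl on a carbonyl carbon; compound 3 `CN(C(=O)NC(=O)c1ccc(Cl)cc1Cl)c1nc(C(F)(F)F)c(C(=O)N/N=C/c2cc(C(F)(F)F)cc(C(F)(F)F)c2)s1` and compound 4 `CN(C(=O)NC(=O)c1cccc(C(F)(F)F)c1)c1nc(C(F)(F)F)c(C(=O)N/N=C/c2cc(C(F)(F)F)cc(C(F)(F)F)c2)s1` form a second pair on another core, and the difference between the two cores is not broken down here. In a functional assay on MCF7 cells (Homo sapiens) for inhibition, read by MTT assay, with a stated time of 72 h (a lower number here means a stronger inhibitor, a higher number a weaker inhibitor), compound 1 gives 8.42 ug/mL. In this assay compound 2 gives 6.5 ug/mL. The change between them, (3-(trifluoromethyl)phenyl in place of 2,4-dichlorophenyl on a carbonyl carbon), produced a 1.3-fold lower number from compound 1 to compound 2 (0.11 log units; within the scatter). For compound 3 this assay records only a limit, > 100 ug/mL. That value sits at the limit of > 100 ug/mL in this assay, at which 1 of the 3 values shown sits. The change from compound 3 to compound 4 is 3-(trifluoromethyl)phenyl in place of 2,4-dichlorophenyl on a carbonyl carbon, the same change at the same place as in the first pair. Because a 1.3-fold lower number from compound 1 to compound 2 (0.11 log units; within the scatter) stayed within the scatter, the expected step is likewise small, a step that the limit leaves unreadable from compound 3 to compound 4, with the caveat that the starting point is a limit rather than a number. Compound 4 is accordingly estimated at 130 ug/mL, within a range of 50 ug/mL to 400 ug/mL, and it is likely that this assay again reports only a limit.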

Compound 4, half-maximal inhibitory concentration: 6.08 ug/mL
For compound 4 the middle estimate is 21-fold (1.33 log units) above the measured one; the measured number lies below the stated range.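

On the second core, 3-(trifluoromethyl)phenyl in place of 2,4-dichlorophenyl on a carbonyl carbon gives an at least 16-fold lower number from compound 3 to compound 4 (1.21 log units; beyond the scatter). The change therefore does not carry over in size between the two cores in this assay: the same change on two cores in this assay, a 1.3-fold lower number (0.11 log units; within the scatter) from compound 1 to compound 2 and an at least 16-fold lower number (1.21 log units; beyond the scatter) from compound 3 to compound 4, at least 12-fold (1.10 log units) apart, beyond the scatter of two such steps

Going by these compounds, compound 3 stands at > 100 ug/mL, which is a limit of the assay and not a number, so the true size of the step on the second core remains unknown, and two cores give no rule for how the change would behave on any other core.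

Among the compounds shown here, only two aryl groups appear on the carbonyl carbon, so it remains open whether a phenyl ring bearing an amine or a carboxylic acid, or a saturated group such as cyclohexyl or a longer alkyl chain, would follow the step on the first core or the one on the second. Also open, on these data alone, is whether the gap between the two steps would hold in cell lines other than MCF7.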